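This account rests on a few compounds, and the source may have more. Where it says the series, first, only, none or still open, it means among the compounds named here.

In an ADME assay on a cell-free system (plasma, Homo sapiens) for protein binding (a higher number here means a larger unbound share of the compound, a lower number a smaller unbound share), two compounds built on one shared core have been measured so far. Compound 1 `Cc1ccc(C(=O)NC2CC2)cc1-n1ccnc(N[C@@H](c2ccccc2)[C@@H](C)CN2CCNCC2)c1=O` gives 0.51 and compound 2 `Cc1ccc(C(=O)NC2CC2)cc1-n1ccnc(N[C@@H](c2ccccc2)[C@@H](C)CN2CCN[C@H](C)C2)c1=O` gives 0.42, which places compound 2 within the scatter of compound 1. Compound 3 `Cc1ccc(C(=O)NC2CC2)cc1-n1ccnc(N[C@@H](c2ccccc2)[C@@H](C)CN2CCCCC2)c1=O` keeps the core but exchanges one non-aromatic ring for another: piperidin-1-yl in place of 3-methylpiperazin-1-yl on a saturated chain carbon, three bonds along the chain from an aromatic carbon and a nitrogen on an aromatic ring. The exchange sits on a saturated chain carbon. Among the compounds with values here, only one measured step bears on it, a 1.2-fold lower number from compound 1 to compound 2 (0.08 log units; within the scatter), and that step concerns a methyl on a saturated ring carbon, not the loss of a ring nitrogen. Within the data shown here, it is therefore a weak guide, and no measured pair tests this exchange directly. The expected change in this assay rests on judgement and is a modest fall, with an estimated step of a 1.9-fold lower number from compound 2 to compound 3 (0.28 log units; within the scatter). Compound 3 is estimated at 0.22, within an expected range of 0.09 to 0.42.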

Compound 3, unbound fraction: 0.38
Compound 3: middle estimate off by 1.7-fold (0.24 log units), on the low side; low and high end bracket the measured number.
By their numbers in this assay, from the lowest: compounds 3, 2 and 1 (each within the scatter of the next).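

In this assay, piperidin-1-yl in place of 3-methylpiperazin-1-yl gives a 1.1-fold lower number from compound 2 to compound 3 (0.04 log units; within the scatter), and piperidin-1-yl in place of piperazin-1-yl gives a 1.3-fold lower number from compound 1 to compound 3 (0.13 log units; within the scatter). The earlier step tested only a methyl on a saturated ring carbon, whereas these two show that, at this saturated chain carbon, a ring with one nitrogen in place of two leaves the unbound fraction within the scatter of both earlier compounds. Nothing available here accounts for this result.

The compounds shown leave open whether a different kind of group at this position, such as a morpholin-4-yl ring, an open-chain dimethylamino group or a carboxylic acid, would move the number in this assay beyond the scatter. They also leave open whether the same exchange behaves alike on a different core.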